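The source may hold more compounds than are shown below. What is called first, only, known or untested is meant among the compounds shown, and "the series" means these compounds.

Compound 1 `COc1ccc(/C=N/NC(=O)Nc2ccc(Oc3ccnc4cc(OCCCN5CCCCC5)c(OC)cc34)c(F)c2)cc1`: 840 nM
Compound 2 `COc1cc2c(Oc3ccc(NC(=O)N/N=C/c4ccc(OC(F)(F)F)cc4)cc3F)ccnc2cc1OCCCN1CCCCC1`: 820 nM

In a functional assay on MDA-MB-231 cells (Homo sapiens) for cytotoxicity, read by MTT assay, with a stated time of 72 h (on this read-out lower numbers stand for stronger inhibition and higher numbers for weaker inhibition), compound 2 holds the lowest of the two numbers, but its distance from compound 1 is within the scatter, so neither compound can be called the stronger. Within the data shown here, the single measured step, a 1.0-fold lower number from compound 1 to compound 2 (0.01 log units; within the scatter), shows that swapping the group on the oxygen of the 4-(trifluoromethoxy)phenyl left the read-out unchanged. Compound 3 `COc1cc2c(Oc3ccc(NC(=O)N/N=C/c4ccncc4)cc3F)ccnc2cc1OCCCN1CCCCC1` differs from compound 2 by pyridin-4-yl in place of 4-(trifluoromethoxy)phenyl on a carbon with a double bond to nitrogen. Among the measured compounds shown here, the measured step bears on this only loosely: it altered a group on that six-membered aromatic ring of carbon only, whereas here the whole ring gives way to pyridin-4-yl, and no measured pair shows such an exchange. The estimate for this change is a modest step, a 1.5-fold higher number from compound 2 to compound 3 (0.17 log units; within the scatter), with wide uncertainty. Compound 3 is therefore expected at 1200 nM, in the range 400 nM to 3500 nM.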

Compound 3, half-maximal inhibitory concentration: 1400 nM
The estimate for compound 3 lay 1.2-fold (0.07 log units) below the measured number; low and high end bracket the measured number.
By their numbers in this assay, from the lowest: compounds 2, 1 and 3 (each within the scatter of the next).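

In this assay, among these compounds, the earlier compounds changed only a group on the six-membered aromatic ring of carbon, whereas here the whole ring gives way to pyridin-4-yl on the carbon with a double bond to nitrogen. This exchange gives a 1.7-fold higher number from compound 2 to compound 3 (0.23 log units; within the scatter), and the exchange for 4-methoxyphenyl gives a 1.7-fold higher number from compound 1 to compound 3 (0.22 log units; within the scatter), so the position tolerates a ring with a hetero atom and no substituent, with both steps staying within the scatter. Nothing available explains these small steps or ties them to any property of the groups.

From the compounds shown here alone, all three compounds lie within the scatter of one another, so it remains open whether any change at this position can move the number beyond it. A cyclohexyl ring, or a phenyl ring bearing a carboxylic acid or a dimethylamino group, could test this.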